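The compounds below may be only part of what the source reports. "The series", "measured", "known", "first", "only" and "open" are said of these compounds alone.

Measured so far:
compound 1, `CCC(=O)N1CCc2nc(C#Cc3ccccc3)sc2C1`: 38 nM
compound 2, `CC1CC(C(=O)N2CCc3nc(C#Cc4ccccc4)sc3C2)C1`: > 10000 nM
compound 3, `O=C(C1CCCCC1)N1CCc2nc(C#Cc3ccccc3)sc2C1`: > 10000 nM

All three share one core and differ only in the group on the carbonyl carbon. In an assay on HEK293 cells for negative allosteric modulation of metabotropic glutamate receptor 5 (Homo sapiens), read by FLIPR, with a stated time of 1 h (on this read-out lower numbers stand for stronger inhibition and higher numbers for weaker inhibition), compound 1 gives 38 nM. Compound 2 reaches only the limit of this assay, > 10000 nM. Compound 3 likewise reaches only the limit, > 10000 nM. Two of the three values thus sit at the same limit (the limit of > 10000 nM in this assay, at which 2 of the 3 values shown sit). The step of an at least 260-fold higher number from compound 1 to compound 2 (2.42 log units; beyond the scatter) and the step of an at least 260-fold higher number from compound 1 to compound 3 (2.42 log units; beyond the scatter) both show that swapping the small ethyl for a carbon ring weakens inhibition sharply. The step that the two limits leave unreadable from compound 2 to compound 3 cannot be sized.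

Compound 4, `O=C(N1CCCC1)N1CCc2nc(C#Cc3ccccc3)sc2C1`, is not yet measured. It differs from compound 3 in one place: pyrrolidin-1-yl in place of cyclohexyl on a carbonyl carbon. Within the data shown here, no measured pair covers a ring bearing a nitrogen on this carbonyl carbon, so the nearest guide is that both ring groups tried so far, in compound 2 and compound 3, landed at the limit. The step of an at least 1.6-fold lower number from compound 3 to compound 4 (0.22 log units; that floor lies within the scatter) that this estimate means is therefore expected to be small. Compound 4 is estimated at 6000 nM in this assay, within a range from 800 nM to 20000 nM.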

Compound 4, half-maximal inhibitory concentration: > 10000 nM
Compound 4: only a limit was reported; the forecaster's own chance of this, stated with the estimate: 55%; middle value at least 1.6-fold (0.22 log units) from the limit.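

Compound 4 carries the question from rings of carbon only to a ring with a nitrogen: pyrrolidin-1-yl on the carbonyl carbon. In this assay, the change from ethyl to this group gives an at least 260-fold higher number from compound 1 to compound 4 (2.42 log units; beyond the scatter), so a nitrogen-containing ring loses inhibition just as the carbon rings of compound 2 and compound 3 do. Compound 4 gives only a limit, > 10000 nM, and the steps among compound 2, compound 3 and compound 4 cannot be read, so no order among these three rings can be told, and all that can be said is that none of them comes near compound 1: the limit of > 10000 nM in this assay, at which 3 of the 4 values shown sit.

On these data alone, whether the loss comes with any ring or simply with any group larger than ethyl stays open, and open chains such as propyl or butyl, or a smaller ring such as cyclopropyl, would bear on that. A dimethylamino group on the same carbonyl carbon would also show whether a nitrogen there can keep inhibition when it is not part of a ring.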